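From 4-methylphenyl to pyridin-2-yl on a shared core

The source may hold more compounds than are shown below. What is called first, only, known or untested is meant among the compounds shown, and "the series" means these compounds.

Compound 1 `Cc1cccc(-c2cc(-c3ccoc3)cc(-c3ccc(Cl)s3)n2)c1`: 880 nM
Compound 2 `Cc1ccc(-c2cc(-c3ccoc3)cc(-c3ccc(Cl)s3)n2)cc1`: 1170 nM

In a functional assay on HCT-15 cells (Homo sapiens) for cytotoxicity, read by ELISA, with a stated time of 4 days (a lower number here means a stronger inhibitor, a higher number a weaker inhibitor), compound 2 stands at 1170 nM, level with compound 1 within the usual scatter. For the measured compounds named here, the only measured step is a 1.3-fold higher number from compound 1 to compound 2 (0.12 log units; within the scatter), and it swaps 3-methylphenyl for 4-methylphenyl. Compound 3 `Clc1ccc(-c2cc(-c3ccoc3)cc(-c3ccccn3)n2)s1` carries pyridin-2-yl in place of 4-methylphenyl on an aromatic carbon, next to the ring nitrogen: pyridin-2-yl in place of 4-methylphenyl on an aromatic carbon. Going by the values given here, no measured step exchanges the aryl ring itself, so the data give no direction for this change. Among the compounds with values here, the small size of a 1.3-fold higher number from compound 1 to compound 2 (0.12 log units; within the scatter) is the only guide, and it comes from a different change, so no step beyond the scatter is expected in this assay, though with wide uncertainty. The estimated step is a 1.1-fold higher number from compound 2 to compound 3 (0.05 log units; within the scatter). For compound 3 the expected value is 1300 nM, with an estimated range from 400 nM to 4000 nM.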

Compound 3, half-maximal inhibitory concentration: 1270 nM
Compound 3: the middle estimate sits 1.0-fold (0.01 log units) above what was measured, within the range that was stated.
By their numbers in this assay, from the lowest: compounds 1, 2 and 3 (each within the scatter of the next).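

In this assay the aryl ring itself is now exchanged at this position, not just the place of its methyl group: there is a 1.1-fold higher number from compound 2 to compound 3 (0.04 log units; within the scatter), and a 1.4-fold higher number from compound 1 to compound 3 (0.16 log units; within the scatter). Pyridin-2-yl brings a ring nitrogen and a hydrogen-bond acceptor that neither methylphenyl group has, and it has no methyl group, yet compounds 1, 2 and 3 cannot be told apart in this assay. No measurement shown offers an explanation for this.

As far as these compounds go, all three compounds carry a six-membered aromatic ring at this carbon, so it remains open how an amine, a carboxylic acid, a longer alkyl chain or even pyridin-4-yl would behave there. From the compounds shown here alone, the furan-3-yl and 5-chlorothiophen-2-yl groups stay the same throughout, so their contribution also remains open.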